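From Benzyl to 4-Nitrophenyl: Estimating Compound 4

The source may report more compounds than this note shows. Statements on the series, on what has been measured and on what is new or still open speak of the compounds shown alone.

In a functional assay on LNCaP cells (Prostate gland, Homo sapiens) for antiproliferative activity, read by sulforhodamine B assay (a lower number here means a stronger inhibitor, a higher number a weaker inhibitor), compound 1 `CCCCCCCCCCCCCCCCCCNC(=O)[C@H]1CSC(Cc2ccccc2)N1` gives 4400 nM, the highest of the three measured numbers, so it is the weakest inhibitor shown. Compound 2 `CCCCCCCCCCCCCCCCCCNC(=O)[C@H]1CSC(c2c[nH]c3ccccc23)N1` gives 2100 nM and compound 3 `CCCCCCCCCCCCCCCCCCNC(=O)[C@H]1CSC(c2cccc(O)c2)N1` gives 1700 nM. Each of these carries an aromatic ring joined directly to the saturated ring carbon where compound 1 carries benzyl, and both steps were modest: a 2.1-fold lower number from compound 1 to compound 2 (0.32 log units; beyond the scatter) and a 2.6-fold lower number from compound 1 to compound 3 (0.41 log units; beyond the scatter). Compound 4 `CCCCCCCCCCCCCCCCCCNC(=O)[C@H]1CSC(c2ccc([N+](=O)[O-])cc2)N1` makes a change of the same kind: 4-nitrophenyl in place of benzyl on a saturated ring carbon. Those two steps bear on it, each beyond the scatter yet small. For compound 4 a similar modest drop in this assay is expected: a 2.2-fold lower number from compound 1 to compound 4 (0.34 log units; beyond the scatter). The estimate for compound 4 is 2000 nM, with a range from 900 nM to 4500 nM.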

Compound 4, half-maximal inhibitory concentration: 8400 nM
Beside the measured number, compound 4's estimate is 4.2-fold (0.62 log units) below it, and the stated range ends below it.
By their numbers in this assay, from the lowest: compounds 3 and 2 (each within the scatter of the next); then compounds 1 and 4 (each within the scatter of the next).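

Putting 4-nitrophenyl in place of benzyl on this saturated ring carbon gives a 1.9-fold higher number from compound 1 to compound 4 (0.28 log units; within the scatter) in this assay and so brings no gain, which shows that an aromatic ring joined directly to this carbon does not by itself lower the number. The choice of ring group also counts at this position, as 4-nitrophenyl in place of 3-hydroxyphenyl gives a 4.9-fold higher number from compound 3 to compound 4 (0.69 log units; beyond the scatter) and in place of 1H-indol-3-yl gives a 4.0-fold higher number from compound 2 to compound 4 (0.60 log units; beyond the scatter) here.

Still open, going by these compounds, is whether a 4-aminophenyl or 4-carboxyphenyl group on this carbon would fall with compound 2 and compound 3 or with compound 4. No measurement at hand offers a reason for the gap between these ring groups.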